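A few compounds are considered here, and "the series" means these few. Any claim that something is new, unique, unknown or untested is made for them only; others in the source may bear on it.

Working notes on the furan-linked diamine series.

Three members are measured in an assay on cells for inhibition of protein arginine N-methyltransferase 1 (Homo sapiens), read by scintillation counting, with stated times of 15 min and 60 min, tested at 9 uM; on this read-out lower numbers stand for less inhibition and higher numbers for more inhibition at the one concentration tested (going by the name of the read-out). Compound 1 `CNCCN(C)Cc1ccc(-c2cccc(OC)c2)o1` gives 37%. Compound 2 `CNCCN(C)Cc1ccc(-c2ccc(OC)cc2)o1` is built from the same atoms as compound 1 joined differently; in this assay compound 2 gives 38%. The difference between the two cores is not broken down here, and the two numbers sit within the scatter of one another. Compound 3 `CNCCN(C)Cc1ccc(-c2cccc(C#N)c2)o1` gives 33%.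

One structural change is seen twice among the compounds. From compound 1 to compound 3 it is cyano in place of methoxy on an aromatic carbon and the step is a number 4 percentage points lower from compound 1 to compound 3 (within the scatter), a change that in this assay did not move the read-out beyond the scatter.

Compound 4 `CNCCN(C)Cc1ccc(-c2ccc(C#N)cc2)o1` is not yet measured. Relative to compound 2 the change is cyano in place of methoxy on an aromatic carbon. The place lines are not the same word for word: for compound 3 the cyano sits meta to a large group, for compound 4 it sits para to a large group, so the change is of the same kind as that from compound 1 to compound 3, not the same change.

The expectation for compound 4 rests on compound 2 with 38% and on the earlier step of a number 4 percentage points lower from compound 1 to compound 3 (within the scatter). The step from compound 2 to compound 4 is expected to be a number 4 percentage points lower from compound 2 to compound 4 (within the scatter), of the same order as the earlier one and within the scatter. On that basis compound 4 is estimated to give 34% in this assay, with a plausible range from 22% to 46%.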

Compound 4, a percentage reported as inhibition, at one concentration (the size of the read-out at that concentration, not a potency): 35%
Beside the measured number, compound 4's estimate is 1 percentage points below it, and the stated range covers the measured number.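

In this assay, cyano in place of methoxy on the core of compound 2 gives a number 3 percentage points lower from compound 2 to compound 4 (within the scatter), and set beside the earlier step on the core of compound 1, the two steps agree: the same change on two cores in this assay, a number 4 percentage points lower (within the scatter) from compound 1 to compound 3 and a number 3 percentage points lower (within the scatter) from compound 2 to compound 4, 1 percentage points apart, within the scatter of two such steps

Within this small set, the change therefore carries from one core to the other without moving the read-out beyond the scatter, even though the cyano sits para to a large group in compound 4 and at another place in compound 3. Going by these compounds alone, this does not show that cyano and methoxy are truly equivalent, nor that the change would behave in the same way on any other core, since both steps are small, only two cores are compared, and each number is the size of the read-out at one concentration, not a potency.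

The compounds shown leave open whether any replacement on the aromatic ring, such as an amine or a carboxylic acid, would shift the inhibition beyond the scatter. They also leave open what a longer chain between the two nitrogens of the diamine would do to the read-out, and whether the cyano-for-methoxy step would still hold on such a core.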